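Cyanophenyl Replaces Fluorophenyl on a Fused Azole Nitrogen

This account rests on a few compounds, and the source may have more. Where it says the series, first, only, none or still open, it means among the compounds named here.

Measured so far in a functional assay on HepG2 cells (Homo sapiens) for inhibition, read by sulforhodamine B assay, with a stated time of 72 h, tested at 10 uM; on this read-out lower numbers stand for less inhibition and higher numbers for more inhibition at the one concentration tested (going by the name of the read-out):
compound 1, `C[C@H](Nc1ncnc2[nH]cnc12)c1nn(-c2cccnc2)c2ccc(F)cc12`, gives 8%
compound 2, `C[C@H](Nc1ncnc2[nH]cnc12)c1nn(-c2cccc(F)c2)c2cc(F)ccc12`, gives 33%
compound 3, `C[C@H](Nc1nc(N)nc2[nH]cnc12)c1nn(-c2cccnc2)c2cc(F)ccc12`, gives 11%

Among these three, compound 2 stands highest in this assay. Its nearest neighbour is compound 3, whose value is lower by an amount beyond the usual scatter, and compound 1 lies further below, again beyond the scatter. Compounds 1 and 3 both carry a pyridinyl group on the aromatic nitrogen where compound 2 carries the fluorophenyl, and both also differ from compound 2 elsewhere, so no single-point comparison is available.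

The next compound, compound 4, `C[C@H](Nc1ncnc2[nH]cnc12)c1nn(-c2ccc(C#N)cc2)c2cc(F)ccc12`, takes one step from compound 2: 4-cyanophenyl in place of 3-fluorophenyl on an aromatic nitrogen. Within the data shown here, no measured pair in this set isolates such a change, so the expected size of the step rests only on the spread seen across the three measured compounds. Because compound 2 gives 33% while the two other members give markedly lower numbers, a move away from the fluorophenyl is estimated to cost some inhibition, and the step of a number 8 percentage points lower from compound 2 to compound 4 (within the scatter) is expected to be small, within or near the scatter, downward. Compound 4 is therefore estimated at 25%, with a range from 5% to 50%.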

Compound 4, a percentage reported as inhibition, at one concentration (the size of the read-out at that concentration, not a potency): 57%
Estimate against measurement, compound 4: 32 percentage points below, outside the stated range (above it).
By their numbers in this assay, from the lowest: compounds 1 and 3 (each within the scatter of the next); then compound 2; then compound 4.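

Among these compounds, with the rest of the molecule held constant, replacing 3-fluorophenyl with 4-cyanophenyl on the aromatic nitrogen gives the first single-place reading of this position in this assay, a step of a number 24 percentage points higher from compound 2 to compound 4 (beyond the scatter). It shows that the group on this nitrogen can by itself move the inhibition read at the one concentration tested, and that a phenyl ring bearing a nitrile is accepted here with a gain rather than a loss. No measurement in hand accounts for that gain, so the reason for it remains unknown.

The change alters both the substituent and where it sits on the phenyl ring, so the compounds shown do not tell whether the gain belongs to the nitrile or to its placement, a question that 3-cyanophenyl and 4-fluorophenyl would help to separate. Also open, going by these compounds, is whether other groups on the phenyl ring, such as a carboxylic acid, a primary amide or an amine, would keep, lose or extend the gain seen with compound 4.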